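Adding a methyl to the five-membered ring of compound 3

The source may report more compounds than this note shows. Statements on the series, on what has been measured and on what is new or still open speak of the compounds shown alone.

Working notes on the series around compound 3 `c1ccc(-c2ccns2)c(OCC2=NCCN2)c1`, which in a functional assay for activation of Alpha-1A adrenergic receptor (Homo sapiens), read by calcium flux (on this read-out higher numbers stand for an effect only at larger amounts of compound and lower numbers for an effect already at smaller amounts), gives 5.01 nM, the lowest of the two values read as numbers. For the measured compounds named here, compound 2 `c1cnc(-c2ccccc2OCC2=NCCN2)nc1` gives 1260 nM in this assay, and the step of a 250-fold lower number from compound 2 to compound 3 (2.40 log units; beyond the scatter) is the only readable step in the set. Compound 1 `c1ccc(-c2ccncc2)c(OCC2=NCCN2)c1` reaches only the limit < 100000 nM in this assay (the limit of < 100000 nM in this assay, at which 1 of the 3 values shown sits). The steps a step that the limit leaves unreadable from compound 1 to compound 2 and a step that the limit leaves unreadable from compound 1 to compound 3 therefore stay unreadable.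

Compound 4 `Cc1cnsc1-c1ccccc1OCC1=NCCN1` differs from compound 3 in one place: methyl in place of hydrogen on an aromatic carbon. Going by the values given here, none of the measured steps concerns a methyl; each of them exchanges the whole aryl group on the shared core. Among the compounds with values here, no measured step bears directly on this change, so no step beyond the scatter is expected in this assay, in either direction. Compound 4 is estimated at 6 nM in this assay, within 1.5 nM to 25 nM, a step of a 1.2-fold higher number from compound 3 to compound 4 (0.08 log units; within the scatter) that is expected to stay within the scatter.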

Compound 4, half-maximal effective concentration: 12.6 nM
The estimate for compound 4 lay 2.1-fold (0.32 log units) below the measured number, and the stated range covers the measured number.
By their numbers in this assay, from the lowest: compound 3; then compound 4; then compound 2.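

In this assay, methyl in place of hydrogen on the aromatic carbon next to the ring atom that bears a large group gives a 2.5-fold higher number from compound 3 to compound 4 (0.40 log units; beyond the scatter), so even this single added carbon at this position shifts the number beyond the scatter. The 4-methyl-1,2-thiazol-5-yl group still retains most of the advantage of the 1,2-thiazol-5-yl group over pyrimidin-2-yl, with a 100-fold lower number from compound 2 to compound 4 (2.00 log units; beyond the scatter). Compound 1 stands at a limit and not at a number, and its step to compound 4, like its other steps, cannot be read: the limit of < 100000 nM in this assay, at which 1 of the 4 values shown sits.

From the compounds shown here alone, whether the higher number belongs to methyl alone or extends to other groups at this carbon stays open, for instance fluorine, methoxy or a longer chain such as ethyl. The compounds shown also leave open how a methyl on either of the other ring carbons would read.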